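Aryl Swap on the Shared Core and Cytotoxicity

A few compounds are considered here, and "the series" means these few. Any claim that something is new, unique, unknown or untested is made for them only; others in the source may bear on it.

Compound 3 `NC(=O)c1ccc(-c2cc(Nc3ccc(OC(F)(F)F)cc3)ncn2)cc1` stands at a limit in an ADME assay on BaF3 cells (Mus musculus) for cytotoxicity; on this read-out higher numbers stand for an effect only at larger amounts of compound and lower numbers for an effect already at smaller amounts: compound 3 gives > 10000 nM, a limit rather than a number. Compound 1 `CC(C)Cn1cc(-c2cc(Nc3ccc(OC(F)(F)F)cc3)ncn2)cn1` also returns only a limit, > 10000 nM. Compound 2 `Nc1cccc(-c2cc(Nc3ccc(OC(F)(F)F)cc3)ncn2)c1` likewise stops at a limit, > 10000 nM. The steps a step that the two limits leave unreadable from compound 1 to compound 2, a step that the two limits leave unreadable from compound 1 to compound 3 and a step that the two limits leave unreadable from compound 2 to compound 3 therefore cannot be read, since all three values rest at the limit of > 10000 nM in this assay, at which 3 of the 3 values shown sit. Compound 4 `FC(F)(F)Oc1ccc(Nc2cc(-c3cn[nH]c3)ncn2)cc1` alters the aryl group on the shared core: 1H-pyrazol-4-yl in place of 4-carbamoylphenyl on an aromatic carbon. For the measured compounds named here, no measured step gives a readable size for such a swap. Compound 4 is therefore expected to show a number no higher from compound 3 to compound 4 (the limit leaves the size open), most likely as another limit. Compound 4 is estimated at 10000 nM, between 5000 nM and 30000 nM.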

Compound 4, half-maximal effective concentration: > 10000 nM
Compound 4 was reported as a limit (the forecaster's own chance of this, stated with the estimate: 85%); the middle value sits exactly at the limit.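

In this assay compound 4 also stops at a limit, so its steps from compound 1, compound 2 and compound 3 cannot be read: the limit of > 10000 nM in this assay, at which 4 of the 4 values shown sit. The compounds shown leave open whether any group on the shared core gives a cytotoxic effect that can be put as a number.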